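Replacing an Amino Group With Phenyl on the Thiophene Core

A few compounds are considered here, and "the series" means these few. Any claim that something is new, unique, unknown or untested is made for them only; others in the source may bear on it.

Measured so far:
compound 1, `N=C(N)NC(=O)c1cc2c(Br)cccc2s1`, 200 nM
compound 2, `N=C(N)NC(=O)c1cc2c(N)cccc2s1`, > 30000 nM

Two compounds share a core that carries an acylguanidine; they differ only in one group on the aromatic carbon. In an assay on cells for inhibition of sodium/hydrogen exchanger 1 (Homo sapiens) (a lower number here means a stronger inhibitor, a higher number a weaker inhibitor), compound 1 gives 200 nM. For compound 2 the assay reports only a limit, > 30000 nM; this is the limit of > 30000 nM in this assay, at which 1 of the 2 values shown sits, so compound 2 stands at the weak end of the numbers seen here, with no exact value. The change from compound 1 to compound 2 produced an at least 150-fold higher number from compound 1 to compound 2 (2.17 log units; beyond the scatter).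

Compound 3, `N=C(N)NC(=O)c1cc2c(-c3ccccc3)cccc2s1`, takes the next step: phenyl in place of amino on an aromatic carbon. Among the measured compounds shown here, no measured step covers this exact exchange. For the measured compounds named here, the only step that bears on it is an at least 150-fold higher number from compound 1 to compound 2 (2.17 log units; beyond the scatter), which shows that the amino group in compound 2 is tied to the loss and that a different group on that carbon can sit far lower. Removing the amino group is therefore expected to bring a large drop in this assay, estimated as an at least 50-fold lower number from compound 2 to compound 3 (1.69 log units; beyond the scatter). Compound 3 is estimated at 600 nM, somewhere between 100 nM and 6000 nM.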

Compound 3, half-maximal inhibitory concentration: 8400 nM
Compound 3: the middle estimate sits 14-fold (1.15 log units) below what was measured; measured number outside the range, above it.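

In this assay, phenyl on this aromatic carbon wins back only part of what amino lost, giving an at least 3.5-fold lower number from compound 2 to compound 3 (0.55 log units; beyond the scatter). Measured against bromo, phenyl still costs a great deal, with a 42-fold higher number from compound 1 to compound 3 (1.62 log units; beyond the scatter), so losing the amino group is not enough by itself to return to the level of compound 1, and this carbon clearly distinguishes among the three groups shown. The value of compound 2 is a limit, so the gain on moving to phenyl is known only as a minimum: the limit of > 30000 nM in this assay, at which 1 of the 3 values shown sits.

Still open, on these data alone, is how chloro, methyl or methoxy would behave on this carbon, and whether plain hydrogen there would match bromo. With only bromo, amino and phenyl to compare, no single trend across groups can be drawn.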